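Replacing a bicyclic amide partner on a sulfonyl benzylamide

This account rests on a few compounds, and the source may have more. Where it says the series, first, only, none or still open, it means among the compounds named here.

Measured compounds:
- compound 1 `O=C(NCc1ccc(S(=O)(=O)c2ccc(F)c(F)c2)cc1)c1cc2cnccc2[nH]1`: 58%
- compound 2 `O=C(NCc1ccc(S(=O)(=O)c2ccccc2)cc1)c1cc2ccncc2s1`: 21%

Two compounds have so far been run through an ADME assay on microsomes from liver (Mus musculus) for metabolic stability, read by LC-MS, with a stated time of 30 min, tested at 1 uM; on this read-out higher numbers stand for a more stable compound and lower numbers for a less stable compound. Compound 1 `O=C(NCc1ccc(S(=O)(=O)c2ccc(F)c(F)c2)cc1)c1cc2cnccc2[nH]1` remains at 58%, while compound 2 `O=C(NCc1ccc(S(=O)(=O)c2ccccc2)cc1)c1cc2ccncc2s1` remains at only 21%, the lowest of the two numbers; the gap between them lies beyond the usual scatter. The two differ in more than one place, so the numbers alone say which one fares better, not why.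

Compound 3 `O=C(NCc1ccc(S(=O)(=O)c2ccccc2)cc1)c1ccc2nncn2c1` has not yet been measured. It keeps the sulfonyl benzylamide part of compound 2 and changes only the group on the carbonyl carbon: a group of 9 heavy atoms (6 carbon, 3 nitrogen; one five-membered aromatic ring with 3 hetero atoms, one six-membered aromatic ring with 1 hetero atom) in place of a group of 9 heavy atoms (7 carbon, 1 nitrogen, 1 sulfur; one five-membered aromatic ring with 1 hetero atom, one six-membered aromatic ring with 1 hetero atom), on a carbonyl carbon. Going by the values given here, no measured pair shows the effect of such a swap, so the expectation rests on the starting point of compound 2 alone. Because compound 2 gives 21%, there is room to move upward, and a modest upward step is expected, a number 19 percentage points higher from compound 2 to compound 3 (beyond the scatter), though a step of no size beyond the scatter cannot be ruled out. Compound 3 is therefore expected to remain at about 40%, with a plausible range from 15% to 70%.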

Compound 3, percent of the compound remaining: 47%
Beside the measured number, compound 3's estimate is 7 percentage points below it, and the stated range covers the measured number.
By their numbers in this assay, from the lowest: compound 2; then compound 3; then compound 1.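

Going by these compounds alone, with the sulfonyl benzylamide part held constant, the group on the carbonyl carbon can now be read on its own for the first time: in this assay, the change gives a number 26 percentage points higher from compound 2 to compound 3 (beyond the scatter). The step shows that this position affects the read-out even when the size of the group and the sizes of its rings stay the same, since both groups have 9 heavy atoms and pair a five-membered aromatic ring with a six-membered one, while the atoms shift from 7 carbon, 1 nitrogen and 1 sulfur to 6 carbon and 3 nitrogen, and the hydrogen-bond acceptors rise from 2 to 3. Nothing available explains the size or direction of this step.

Compound 1 differs from both other compounds in more than one place, so the compounds shown leave open whether the same swap would give a similar step on its difluorinated sulfonyl part. They also leave open what a single pyridine ring or a simple phenyl ring on the same carbonyl carbon would give, and so whether the read-out depends on having two fused rings there at all.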